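A Methyl on the Aromatic Nitrogen: Expecting Compound 4

The source may hold more compounds than are shown below. What is called first, only, known or untested is meant among the compounds shown, and "the series" means these compounds.

Compound 1 `CCCCCC(CCO)n1cnc2c(NC)ncnc21` and compound 2 `CCCCCC(CCO)n1cnc2c(N(C)C)ncnc21` share a core and differ by methyl in place of hydrogen on a nitrogen on an aromatic ring. In a functional assay on HCT-116 cells (Homo sapiens) for antiproliferative activity, read by MTT assay, with a stated time of 48 h (a lower number here means a stronger inhibitor, a higher number a weaker inhibitor), compound 1 gives > 50000 nM, which is a limit of the assay rather than a number. In this assay compound 2 likewise gives > 50000 nM, again a limit. The step that the two limits leave unreadable from compound 1 to compound 2 therefore cannot be read, because the limit of > 50000 nM in this assay, at which 2 of the 3 values shown sit, leaves both values at the same limit.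

Compound 3 `CCCCCCCCCCCC(CCO)n1cnc2c(NC)ncnc21` differs from compound 1 by hexyl in place of hydrogen on a saturated chain carbon, six bonds along the chain from an aromatic nitrogen. In this assay, among the compounds with values here, compound 3 gives 15400 nM, the only plain number among the three measured compounds. Within the data shown here, the step of an at least 3.2-fold lower number from compound 1 to compound 3 (0.51 log units; beyond the scatter) is the one readable change in the set.

Compound 4 `CCCCCCCCCCCC(CCO)n1cnc2c(N(C)C)ncnc21` has not been measured. It differs from compound 3 by methyl in place of hydrogen on a nitrogen on an aromatic ring, the same change that turns compound 1 into compound 2, made this time on the core of compound 3 carrying the longer chain. Among the measured compounds shown here, the one earlier instance of this change gives no usable size, so the expectation for compound 4 rests on compound 3 alone, with 15400 nM as the starting point and a wide allowance in both directions. Compound 4 is expected to sit close to compound 3, with an estimated step of a 1.6-fold higher number from compound 3 to compound 4 (0.21 log units; within the scatter). Compound 4 is estimated at 25000 nM in this assay, with a plausible range from 8000 nM to 60000 nM, and a real chance that only a limit is reported.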

Compound 4, half-maximal inhibitory concentration: 12000 nM
Compound 4: the middle estimate sits 2.1-fold (0.32 log units) above what was measured; the range from low to high includes it.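

In this assay, methyl in place of hydrogen on a nitrogen on an aromatic ring, carried onto the core with the longer chain, gives a 1.3-fold lower number from compound 3 to compound 4 (0.11 log units; within the scatter), so on this core the change makes no difference that can be told from the scatter. Hexyl in place of hydrogen on a saturated chain carbon, six bonds along the chain from an aromatic nitrogen, gives an at least 4.1-fold lower number from compound 2 to compound 4 (0.61 log units; beyond the scatter), and this change points the same way on both cores, although its size on each cannot be pinned down: the same change on two cores in this assay, an at least 3.2-fold lower number (0.51 log units; beyond the scatter) from compound 1 to compound 3 and an at least 4.1-fold lower number (0.61 log units; beyond the scatter) from compound 2 to compound 4; the limit leaves it open whether they differ The methyl change cannot be compared across the two cores, and the series shows nothing about its size on the shorter chain, because that step cannot be read: the limit of > 50000 nM in this assay, at which 2 of the 4 values shown sit.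

The compounds shown leave open how the number would respond to a chain longer than the one in compound 3 and compound 4, or to a chain of a length that falls short of it but exceeds the one in compound 1. They also leave open what an unsubstituted amino group, or an ethyl group in place of the methyl on that nitrogen, would give on the shared core.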